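A few compounds are considered here, and "the series" means these few. Any claim that something is new, unique, unknown or untested is made for them only; others in the source may bear on it.

Measured so far in a functional assay on HCT-116 cells (Homo sapiens) for antiproliferative activity, read by MTT assay, with a stated time of 48 h; a higher number here means a weaker inhibitor, a lower number a stronger inhibitor 
compound 1 `O=C(/C=C/c1ccc(/C=C/C(=O)c2cccc(Cl)c2)o1)NO` gives 1510 nM 
compound 2 `O=C(/C=C/c1ccc(/C=C/C(=O)c2ccccc2)o1)NO` gives 2890 nM 

Compound 1 has only compound 2 to stand against, and the two lie within the scatter of each other. Compound 3 `O=C(/C=C/c1ccc(/C=C/C(=O)c2cc(Cl)ccc2Cl)o1)NO` keeps the core of compound 1 and differs in one place (chloro in place of hydrogen on an aromatic carbon), with chloro in place of hydrogen on an aromatic carbon. For the measured compounds named here, the one measured step that bears on this removes a chloro group a 1.9-fold higher number from compound 1 to compound 2 (0.28 log units; within the scatter) and stays within the scatter. No change beyond the scatter is therefore expected in this assay, and the estimated step is a 1.2-fold lower number from compound 1 to compound 3 (0.07 log units; within the scatter) here. The expected value for compound 3 is 1300 nM (estimated range 500 nM to 3500 nM).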

Compound 3, half-maximal inhibitory concentration: 4120 nM
Compound 3: middle estimate off by 3.2-fold (0.50 log units), on the low side; measured number above the stated range.
By their numbers in this assay, from the lowest: compounds 1, 2 and 3 (each within the scatter of the next, the first and the last beyond it).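

In this assay, a chloro group placed on the aromatic carbon ortho to a large group and para to a chloro group gives a 2.7-fold higher number from compound 1 to compound 3 (0.44 log units; beyond the scatter) and so a modest loss of activity. For the compounds shown here, the earlier chloro change, a 1.9-fold higher number from compound 1 to compound 2 (0.28 log units; within the scatter), showed no clear effect, so this is the first chloro change that clearly matters. No measurement shown here explains the loss.

Still open, as far as these compounds go, is whether the loss is specific to chloro or would also occur with another group at this carbon, such as fluoro, methyl or methoxy.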